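Benzoyl to benzylcarbamoyl: compound 3 to compound 4

A few compounds are considered here, and "the series" means these few. Any claim that something is new, unique, unknown or untested is made for them only; others in the source may bear on it.

In a functional assay on PC-3 cells (Homo sapiens) for cytotoxicity, read by MTT assay, with a stated time of 96 h (a lower number here means a stronger inhibitor, a higher number a weaker inhibitor), compound 3 `CC[C@H](N)C(=O)N[C@@H]1C(=O)N2[C@@H](CC[C@@H]1CCNC(=O)c1ccccc1)CC[C@H]2C(=O)NC(c1ccccc1)c1ccccc1` gives > 100000 nM, which is a limit and not a number. Compound 1 `CC[C@H](N)C(=O)N[C@@H]1C(=O)N2[C@@H](CC[C@@H]1CNC(=O)NCc1ccccc1)CC[C@H]2C(=O)NC(c1ccccc1)c1ccccc1` gives > 100000 nM, which is also a limit. Compound 2 `CC[C@H](N)C(=O)N[C@@H]1C(=O)N2[C@@H](CC[C@@H]1CCN)CC[C@H]2C(=O)NC(c1ccccc1)c1ccccc1`, which carries the free amine, gives a number, 85200 nM.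

Compound 4 `CC[C@H](N)C(=O)N[C@@H]1C(=O)N2[C@@H](CC[C@@H]1CCNC(=O)NCc1ccccc1)CC[C@H]2C(=O)NC(c1ccccc1)c1ccccc1` changes one place in compound 3: benzylamino in place of phenyl on a carbonyl carbon. This is benzylamino in place of phenyl on a carbonyl carbon, so benzamidomethyl becomes ((benzylcarbamoyl)amino)methyl.

For the measured compounds named here, three measured steps bear on this change. Placing benzoyl on the amine nitrogen gives an at least 1.1-fold higher number from compound 2 to compound 3 (0.06 log units; that floor lies within the scatter). Exchanging the end groups of the two compounds without a free amine on that chain gives a step that the two limits leave unreadable from compound 1 to compound 3. Moving from the (benzylcarbamoyl)amino group to the free amine gives an at least 1.1-fold lower number from compound 1 to compound 2 (0.06 log units; that floor lies within the scatter). The two readable floors lie within the scatter, and no measured step is shown to go beyond it.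

No step beyond the scatter is expected in this assay because the limit of > 100000 nM in this assay, at which 2 of the 3 values shown sit, takes in both compound 1 and compound 3. The estimated change is a number no higher from compound 3 to compound 4 (the limit leaves the size open). Compound 4 is estimated at 100000 nM, with an expected range of 60000 nM to 200000 nM, and a report as a limit only is the likeliest outcome.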

Compound 4, half-maximal inhibitory concentration: > 100000 nM
Compound 4: no number, only a limit; the forecaster's own chance of this, stated with the estimate: 75%; the middle value lies on the limit itself.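

In this assay compound 4 gives > 100000 nM, which is a limit. Set against the free amine, the only compound in the series with a number, benzylcarbamoyl on the amine nitrogen reads as an at least 1.1-fold higher number from compound 2 to compound 4 (0.06 log units; that floor lies within the scatter), so this cap gives no more of a number than benzoyl does; the steps from compound 3 and from compound 1 to compound 4 cannot be read, as both ends of each are limits. With this result the series still rests on a single number, and most of what can be said about this position is bounded by one ceiling: the limit of > 100000 nM in this assay, at which 3 of the 4 values shown sit.

The compounds shown do not tell whether benzylamino and phenyl differ at all on this carbonyl carbon, nor whether either end group has any effect of its own in this assay. For the compounds shown here, also open is how a carboxylic acid or a sulfonamide on this chain would read, or a longer chain ending in the free amine, the one kind of end group here that gives a number.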